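The compounds below may be only part of what the source reports. "The series", "measured", "known", "first", "only" and "open" are said of these compounds alone.

Of the compounds shown here, three built on one shared core have been tested in an ADME assay on PC-3 cells (Homo sapiens) for cytotoxicity, read by WST assay, tested at 100 uM; on this read-out lower numbers stand for less inhibition and higher numbers for more inhibition at the one concentration tested (going by the name of the read-out). Compound 1 `O=C(Nc1ccc(Cl)cn1)C1CCCN(C(=O)c2cc(C(F)(F)F)cc(C(F)(F)F)c2)C1` gives 0% in this assay. Compound 2 `O=C(Nc1cccc(Oc2ccccn2)c1)C1CCCN(C(=O)c2cc(C(F)(F)F)cc(C(F)(F)F)c2)C1` gives 0%. Compound 3 `COC(=O)c1cccc(NC(=O)C2CCCN(C(=O)c3cc(C(F)(F)F)cc(C(F)(F)F)c3)C2)c1` gives 0%, level with compounds 1 and 2 at the digits shown: none of the three is seen to harm the cells at the concentration used. Two single changes connect the measured compounds to compound 3: no change at the digits printed from compound 1 to compound 3 (within the scatter) and no change at the digits printed from compound 2 to compound 3 (within the scatter). Each exchanges the group that hangs on the amide-type nitrogen, and neither moves the read-out beyond the scatter.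

The step now taken goes from compound 3 to compound 4 `C=CCOc1cccc(NC(=O)C2CCCN(C(=O)c3cc(C(F)(F)F)cc(C(F)(F)F)c3)C2)c1`. allyloxy in place of methoxycarbonyl on an aromatic carbon The rest of the molecule is untouched, so only the substituent on that aromatic ring differs. Both measured steps bear on this one, since no change at the digits printed from compound 1 to compound 3 (within the scatter) and no change at the digits printed from compound 2 to compound 3 (within the scatter) show that swapping groups in exactly this region left the read-out where it was. The expected step is therefore a number 2 percentage points higher from compound 3 to compound 4 (within the scatter), nothing beyond the scatter in either direction. Compound 4 is estimated at 2%, with a range from -8% to 15%.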

Compound 4, a percentage reported as inhibition, at one concentration (the size of the read-out at that concentration, not a potency): 0%
Compound 4: middle estimate off by 2 percentage points, on the high side, and the stated range covers the measured number.
By their numbers in this assay, from the lowest: compounds 1, 2, 3 and 4 (each within the scatter of the next).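

In this assay, putting allyloxy in place of methoxycarbonyl gives no change at the digits printed from compound 3 to compound 4 (within the scatter) and so adds a new kind of group to this position: an ether-linked open chain with a double bond, where compound 3 carried an ester. The comparison with the other compounds points the same way, with allyl in place of pyridin-2-yl on the oxygen giving no change at the digits printed from compound 2 to compound 4 (within the scatter) and 3-(allyloxy)phenyl in place of 5-chloropyridin-2-yl on the amide-type nitrogen giving no change at the digits printed from compound 1 to compound 4 (within the scatter), so these four quite different groups on the amide-type nitrogen all leave the cells reading alike at this single concentration. No measured information is available to explain this flat result.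

Since all four compounds share the same reading, the compounds shown do not reveal which change at this position, if any, would produce a measurable effect on these cells. Going by these compounds, it remains open whether an amine, a carboxylic acid or a longer chain in place of allyloxy would keep the reading level, and whether replacing the two trifluoromethyl groups of the shared core would do the same.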